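The source may report more compounds than this note shows. Statements on the series, on what has been measured and on what is new or still open speak of the compounds shown alone.

Within the data shown here, the three compounds measured so far were tested in an ADME assay on HepG2 cells (Homo sapiens) for cytotoxicity, with a stated time of 72 h; on this read-out lower numbers stand for an effect already at smaller amounts and higher numbers for an effect only at larger amounts of compound. Compound 1 `O=C(Nc1nc(-c2ccc(Cl)cc2)cs1)c1cc([N+](=O)[O-])ccc1Cl` gave a value recorded only as a limit of the assay, > 27000 nM. Compound 2 `Cc1ccc(-c2nc3ccccc3o2)cc1NC(=O)c1cc([N+](=O)[O-])ccc1Cl` likewise gave only a limit, > 14000 nM. Compound 3 `O=C(Nc1ccc(Cl)c(-c2nc3ccccc3s2)c1)c1cc([N+](=O)[O-])ccc1Cl` also reached only a limit, > 25000 nM. Compound 2 therefore stands at a limit rather than at a number, namely (the limit of > 14000 nM in this assay, at which 1 of the 3 values shown sits), and the two other compounds stand at limits as well, so that nothing on this read-out distinguishes compound 2 from compound 1 or compound 3. Among the measured compounds shown here, no step between measured compounds is available, since each value is a limit.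

Compound 4 `COc1ccc(-c2nc3ccccc3o2)cc1NC(=O)c1cc([N+](=O)[O-])ccc1Cl` has not yet been measured in this assay. It differs from compound 2 in one place: methoxy in place of methyl on an aromatic carbon. For the measured compounds named here, with every measured value a limit, no measured step shows what any change does to this read-out. Compound 4 is therefore expected to behave much as compound 2 does. The expected step is a step that the limit leaves unreadable from compound 2 to compound 4, which is none beyond the usual scatter. The estimate for compound 4 in this assay is 20000 nM, within a range from 8000 nM to 50000 nM, and most likely it too will be recorded only as a limit.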

Compound 4, half-maximal effective concentration: > 25000 nM
Compound 4: a limit, no number; the forecaster's own chance of this, stated with the estimate: 80%; at least 1.2-fold (0.09 log units) between middle value and limit.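

Among these compounds, compound 2 and compound 4 both gave only a limit of the assay, so no step between them can be read in this assay. The compounds shown leave open the half-maximal effective concentration of each of them, and whether methoxy in place of methyl on an aromatic carbon changes it at all.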